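Chloro for methyl on the indole ring of compound 3

A few compounds are considered here, and "the series" means these few. Any claim that something is new, unique, unknown or untested is made for them only; others in the source may bear on it.

Three compounds have been measured in a functional assay on SW1573 cells (Homo sapiens) for inhibition, read by sulforhodamine B assay, with a stated time of 48 h; on this read-out lower numbers stand for stronger inhibition of growth and higher numbers for weaker inhibition of growth:
Compound 1 `COC(=O)[C@@]1(C)CCC=C2[C@@H]1CC[C@@H](C)[C@]2(C)Cc1c[nH]c2ccc(C)cc12`: 15000 nM
Compound 2 `COC(=O)[C@@]1(C)CCC=C2[C@@H]1CC[C@@H](C)[C@]2(C)Cc1c[nH]c2ccc(Cl)cc12`: 11000 nM
Compound 3 `COC(=O)[C@@]1(C)CCC=C2[C@@H]1CC[C@@H](C)[C@]2(C)Cc1c(C)[nH]c2ccc(C)cc12`: 18000 nM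

Compound 3 shows the highest number of the three, but its gaps to compound 1 and compound 2 are both within the scatter, so the three compounds cannot be ranked on this assay. Compound 4 `COC(=O)[C@@]1(C)CCC=C2[C@@H]1CC[C@@H](C)[C@]2(C)Cc1c(C)[nH]c2ccc(Cl)cc12` differs from compound 3 by chloro in place of methyl on an aromatic carbon. The same change has been made once before, in the pair lacking the second methyl on the five-membered ring: a 1.4-fold lower number from compound 1 to compound 2 (0.13 log units; within the scatter). The other measured step, a 1.2-fold higher number from compound 1 to compound 3 (0.08 log units; within the scatter), concerns a different position and adds nothing on the chloro question. Within the data shown here, with only one step bearing on the change, and that step within the scatter, no shift beyond the scatter is expected from compound 3 to compound 4 in this assay; the expected step is a 1.3-fold lower number from compound 3 to compound 4 (0.11 log units; within the scatter). Compound 4 is therefore estimated at 14000 nM, with a range from 7000 nM to 28000 nM.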

Compound 4, concentration for 50% growth inhibition: 14000 nM
Estimate against measurement, compound 4: no gap at the digits printed; low and high end bracket the measured number.
By their numbers in this assay, from the lowest: compounds 2, 4, 1 and 3 (each within the scatter of the next).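

In this assay, chloro in place of methyl on an aromatic carbon can now be read on a second core, as a 1.3-fold lower number from compound 3 to compound 4 (0.11 log units; within the scatter), and the two readings agree: the same change on two cores in this assay, a 1.4-fold lower number (0.13 log units; within the scatter) from compound 1 to compound 2 and a 1.3-fold lower number (0.11 log units; within the scatter) from compound 3 to compound 4, 1.1-fold (0.03 log units) apart, within the scatter of two such steps. Methyl in place of hydrogen on an aromatic carbon also gains a second reading, a 1.3-fold higher number from compound 2 to compound 4 (0.10 log units; within the scatter), and again the two agree: the same change on two cores in this assay, a 1.2-fold higher number (0.08 log units; within the scatter) from compound 1 to compound 3 and a 1.3-fold higher number (0.10 log units; within the scatter) from compound 2 to compound 4, 1.1-fold (0.03 log units) apart, within the scatter of two such steps. Each change therefore stays within the scatter on both cores, and among these four compounds neither alters the size of the other.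

As far as these compounds go, with methyl and chloro alone at this place and all four compounds within the scatter of the next, it remains open whether any group on this aromatic carbon can shift the number beyond the scatter. An amine, a carboxylic acid or a longer chain there would address that question.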